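Naphthyl in place of iodophenyl on a nucleotide side chain

The source may hold more compounds than are shown below. What is called first, only, known or untested is meant among the compounds shown, and "the series" means these compounds.

Compound 2 `O=c1[nH]/c(=N\OCCCc2cccc(I)c2)ccn1[C@@H]1O[C@H](COP(=O)(O)OP(=O)(O)OP(=O)(O)O)[C@@H](O)[C@H]1O` gives 114 nM in a functional assay on 1321-N1 cells for agonist activity at P2Y purinoceptor 4 (Homo sapiens), read by scintillation counting and inositol phosphate accumulation; a lower number here means that less compound is needed, a higher number that more compound is needed for the effect. Compound 1 `O=c1[nH]/c(=N\OCCCc2cccc(F)c2)ccn1[C@@H]1O[C@H](COP(=O)(O)OP(=O)(O)OP(=O)(O)O)[C@@H](O)[C@H]1O` gives 100 nM in this assay, and the step of a 1.1-fold higher number from compound 1 to compound 2 (0.06 log units; within the scatter) shows that these two halogens behave alike. Compound 2 has the highest of the two numbers, but compound 1 sits within the scatter of it. Compound 3 `O=c1[nH]/c(=N\OCCCc2ccc3ccccc3c2)ccn1[C@@H]1O[C@H](COP(=O)(O)OP(=O)(O)OP(=O)(O)O)[C@@H](O)[C@H]1O` differs from compound 2 by naphthalen-2-yl in place of 3-iodophenyl on a saturated chain carbon, three bonds along the chain from an oxygen. Only the halogen swap bears on this change, and it was within the scatter, so a small step is expected in this assay, with no clear direction: a 1.1-fold higher number from compound 2 to compound 3 (0.06 log units; within the scatter). Compound 3 is estimated at 130 nM, between 40 nM and 500 nM.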

Compound 3, half-maximal effective concentration: 128 nM
Compound 3: the middle estimate sits 1.0-fold (0.01 log units) above what was measured; the range from low to high includes it.
By their numbers in this assay, from the lowest: compounds 1, 2 and 3 (each within the scatter of the next).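

In this assay, naphthalen-2-yl, with its 2 six-membered aromatic rings, can stand in for a single-ring group at this place on the chain: the result is a 1.1-fold higher number from compound 2 to compound 3 (0.05 log units; within the scatter) and a 1.3-fold higher number from compound 1 to compound 3 (0.11 log units; within the scatter). The earlier compounds shown here showed only that one halogen could replace another, whereas these steps show the same closeness when a whole second ring enters. Nothing available explains why these groups give such similar numbers. The compounds shown leave open whether an amine or a carboxylic acid on the ring would keep the number in this range, and whether a longer chain would.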